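A few compounds are considered here, and "the series" means these few. Any claim that something is new, unique, unknown or untested is made for them only; others in the source may bear on it.

Measured in a functional assay on HepG2 cells (Homo sapiens) for inhibition, read by MTT assay, with a stated time of 3 days; a lower number here means a stronger inhibitor, a higher number a weaker inhibitor:
- compound 1 `CC[C@H](C)[C@H](NCC(=O)NNC(=O)COc1ccc(-c2nc3ccccc3s2)cc1OC)C(=O)O`: 3540 nM
- compound 2 `COc1cc(-c2nc3ccccc3s2)ccc1OCC(=O)NNC(=O)CN[C@@H](CCSC)C(=O)O`: 3780 nM
- compound 3 `CCOC(=O)CN(C)CC(=O)NNC(=O)COc1ccc(-c2nc3ccccc3s2)cc1OC`: 3180 nM

Compound 3, at 3180 nM, cannot be separated from the other two compounds. The steps are a 1.1-fold lower number from compound 1 to compound 3 (0.05 log units; within the scatter) and a 1.2-fold lower number from compound 2 to compound 3 (0.08 log units; within the scatter), and the remaining one is a 1.1-fold higher number from compound 1 to compound 2 (0.03 log units; within the scatter).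

Next in the series is compound 4 `CCOC(=O)[C@@H](NCC(=O)NNC(=O)COc1ccc(-c2nc3ccccc3s2)cc1OC)[C@@H](C)CC`, reached from compound 3 by this change: (1-(ethoxycarbonyl)-2-methylbutyl)amino in place of ((ethoxycarbonyl)methyl)(methyl)amino on a saturated chain carbon bound to a carbonyl carbon. In words, (1-(ethoxycarbonyl)-2-methylbutyl)amino stands in place of ((ethoxycarbonyl)methyl)(methyl)amino on a saturated chain carbon bound to a carbonyl carbon.

Among the measured compounds shown here, no measured compound carries the entering group itself, so the evidence is indirect. Two measured steps exchange the same leaving group at this place. One is a 1.1-fold lower number from compound 1 to compound 3 (0.05 log units; within the scatter), with (1-carboxy-2-methylbutyl)amino on the other side, and the other is a 1.2-fold lower number from compound 2 to compound 3 (0.08 log units; within the scatter), with (1-carboxy-3-(methylsulfanyl)propyl)amino on the other side. For the measured compounds named here, both stay within the scatter, and no measured step in this small set goes beyond it. No step beyond the scatter is therefore expected in this assay, and no direction can be assigned.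

The estimated change is a 1.1-fold higher number from compound 3 to compound 4 (0.03 log units; within the scatter). For compound 4 the expected value is 3400 nM, with an estimated range of 1800 nM to 6500 nM.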

Compound 4, half-maximal inhibitory concentration: 3460 nM
Compound 4: the middle estimate sits 1.0-fold (0.01 log units) below what was measured; low and high end bracket the measured number.
By their numbers in this assay, from the lowest: compounds 3, 4, 1 and 2 (each within the scatter of the next).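

In this assay, the exchange on a saturated chain carbon bound to a carbonyl carbon gives a 1.1-fold higher number from compound 3 to compound 4 (0.04 log units; within the scatter) even though the entering group brings a hydrogen-bond donor and defined stereocentres that the leaving group lacks, so this position tolerates both without a readable shift. The series now also holds a direct pair for the acid and its ester: ethyl in place of hydrogen on an oxygen next to a carbonyl group gives a 1.0-fold lower number from compound 1 to compound 4 (0.01 log units; within the scatter) and thus separates the free carboxylic acid from the ethyl ester in no way. Exchanging 1-carboxy-3-(methylsulfanyl)propyl for 1-(ethoxycarbonyl)-2-methylbutyl on an amine nitrogen alters the side chain and the ester together, and it still gives only a 1.1-fold lower number from compound 2 to compound 4 (0.04 log units; within the scatter) in this assay. Nothing at hand explains why these numbers stay so close.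

Open, as far as these compounds go, is whether a longer alkyl chain, a free primary amine or a second carboxylic acid at this place would produce a step beyond the scatter. Also open, from the compounds shown here alone, is whether the opposite configuration at the defined stereocentres of compound 4 would change the number.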